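Ring size at the chain carbon and EP3 binding

This account rests on a few compounds, and the source may have more. Where it says the series, first, only, none or still open, it means among the compounds named here.

Compound 1 `CCC(CC)C(/C=C1\OC(=O)NC1=O)c1ccc(-c2ccc3cccc(F)c3c2)[nH]c1=O`: 13 nM
Compound 2 `O=C1NC(=O)/C(=C/C(c2ccc(-c3ccc4cccc(F)c4c3)[nH]c2=O)C2CCCCC2)O1`: 4 nM
Compound 3 `O=C1NC(=O)/C(=C/C(c2ccc(-c3ccc4cccc(F)c4c3)[nH]c2=O)C2CC2)O1`: 22 nM

In an assay on membranes from Chem-1 cells for displacement of a labelled ligand from prostaglandin E2 receptor EP3 subtype (Homo sapiens), read by scintillation counting, with a stated time of 2 h (on this read-out lower numbers stand for stronger inhibition and higher numbers for weaker inhibition), compound 3 gives the highest of the three numbers; its nearest neighbour is compound 1, and the step of a 1.7-fold higher number from compound 1 to compound 3 (0.23 log units; within the scatter) stays within the scatter, whereas a 5.5-fold higher number from compound 2 to compound 3 (0.74 log units; beyond the scatter) lies beyond it. Compound 4 `O=C1NC(=O)/C(=C/C(c2ccc(-c3ccc4cccc(F)c4c3)[nH]c2=O)C2CCCC2)O1` carries cyclopentyl in place of cyclopropyl on a saturated chain carbon bound to an aromatic carbon and a double-bonded chain carbon. Going by the values given here, the steps that bear on this are a 5.5-fold higher number from compound 2 to compound 3 (0.74 log units; beyond the scatter) and a 1.7-fold higher number from compound 1 to compound 3 (0.23 log units; within the scatter): enlarging the ring from three to six members gave a modest drop in the number. Cyclopentyl sits between cyclopropyl and cyclohexyl, so a modest lowering is expected in this assay, a 3.1-fold lower number from compound 3 to compound 4 (0.50 log units; beyond the scatter). Compound 4 is therefore estimated at 7 nM, with a range from 2.5 nM to 18 nM.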

Compound 4, inhibition constant: 9 nM
Estimate against measurement, compound 4: 1.3-fold (0.11 log units) below, and the stated range covers the measured number.
By their numbers in this assay, from the lowest: compound 2; then compounds 4, 1 and 3 (each within the scatter of the next, the first and the last beyond it).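

In this assay the cyclopentyl group adds a third ring size at this saturated chain carbon, and it stands apart from both other rings: a 2.4-fold lower number from compound 3 to compound 4 (0.39 log units; beyond the scatter) and a 2.3-fold higher number from compound 2 to compound 4 (0.35 log units; beyond the scatter) are each beyond the scatter, so among these three rings the number falls as the ring grows. The open-chain pentan-3-yl group does not separate from cyclopentyl, with a 1.4-fold lower number from compound 1 to compound 4 (0.16 log units; within the scatter) staying within the scatter. Nothing shown here gives a reason for this order.

As far as these compounds go, whether cycloheptyl would extend the trend remains open, as does how a ring containing oxygen, such as tetrahydropyran-4-yl, would compare.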